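The source may hold more compounds than are shown below. What is called first, only, known or untested is meant among the compounds shown, and "the series" means these compounds.

Compound 1, `COc1ccc(-c2sc(C(=O)O)cc2-c2cc(OC)c(OC)c(OC)c2)cc1O`, gives 11200 nM in a functional assay on KB cells (Homo sapiens) for antiproliferative activity, read by MTT assay, with a stated time of 72 h; on this read-out lower numbers stand for stronger inhibition and higher numbers for weaker inhibition.
Compound 2, `COc1ccc(-c2sccc2-c2cc(OC)c(OC)c(OC)c2)cc1O`, gives 6270 nM.
Compound 3, `COc1ccc(-c2cc(C(=O)O)sc2-c2cc(OC)c(OC)c(OC)c2)cc1`, gives 8650 nM.

The change from compound 1 to compound 2 is hydrogen in place of carboxy on an aromatic carbon, and it produced a 1.8-fold lower number from compound 1 to compound 2 (0.25 log units; within the scatter). Compound 4, `COc1ccc(-c2ccsc2-c2cc(OC)c(OC)c(OC)c2)cc1`, is not yet measured; it arises from compound 3 by hydrogen in place of carboxy on an aromatic carbon. This is the same kind of change, though the surroundings differ: the ring atom two ring bonds away bears a 4-methoxyphenyl group in compound 3 but a 3-hydroxy-4-methoxyphenyl group in compound 1. The difference between the two cores of compound 1 and compound 3 is not broken down here. For compound 4 the expected step is a 1.8-fold lower number from compound 3 to compound 4 (0.26 log units; within the scatter) in this assay. That expectation rests on compound 1 and compound 2, whose change gave a 1.8-fold lower number from compound 1 to compound 2 (0.25 log units; within the scatter). Compound 4 is therefore estimated at 4800 nM, between 2000 nM and 12000 nM.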

Compound 4, half-maximal inhibitory concentration: 7400 nM
Estimate against measurement, compound 4: 1.5-fold (0.19 log units) below; the measured number falls inside the stated range.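

Putting hydrogen in place of the carboxy group on the core of compound 3 gave a 1.2-fold lower number from compound 3 to compound 4 (0.07 log units; within the scatter) in this assay. Set beside the same change on the core of compound 1, the two results agree: the same change on two cores in this assay, a 1.8-fold lower number (0.25 log units; within the scatter) from compound 1 to compound 2 and a 1.2-fold lower number (0.07 log units; within the scatter) from compound 3 to compound 4, 1.5-fold (0.18 log units) apart, within the scatter of two such steps. On these two cores, then, the change carries over in the sense that neither step rises beyond the scatter, but two pairs cannot show that this holds on other cores, and they do not explain why.

As far as these compounds go, it remains open whether a different group at the same place, such as an amine or a methyl ester, would move the number beyond the scatter. Also open, from the compounds shown here alone, is how the change would behave on a core with a much lower number.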